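Working notes: from compound 2 to compound 3

The source may hold more compounds than are shown below. What is called first, only, known or untested is meant among the compounds shown, and "the series" means these compounds.

Of the compounds shown here, two have been read so far in an ADME assay on HeLa cells (Homo sapiens) for cytotoxicity; on this read-out lower numbers stand for higher toxicity in this test and higher numbers for lower toxicity in this test. Compound 1, `COC(=O)CCCNC(=O)c1cc(C)cc2c1NC(C)(C)C=C2C`, gives > 30000 nM, which is a limit of the assay and not a number. Compound 2, `COC(=O)CCCNC(=O)c1cccc2c1NCCC2`, gives > 30000 nM, which is also a limit and not a number. Compound 2 therefore shares its standing with compound 1: the limit of > 30000 nM in this assay, at which 2 of the 2 values shown sit.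

Compound 3, `COC(=O)/C=C/CNC(=O)c1cccc2c1NCCC2`, differs from compound 2 in one place: 2-(methoxycarbonyl)ethenyl in place of 2-(methoxycarbonyl)ethyl on a saturated chain carbon bound to an amide-type nitrogen. In words, 2-(methoxycarbonyl)ethenyl stands in place of 2-(methoxycarbonyl)ethyl on a saturated chain carbon bound to an amide-type nitrogen. Among the compounds with values here, the series holds no measured step between compounds that differ in one place, so the size of this change in this assay has no direct precedent.

The expectation starts from compound 2, whose > 30000 nM is a limit. No shift in either direction beyond the scatter is expected, and the estimated move is an at least 1.2-fold lower number from compound 2 to compound 3 (0.07 log units; that floor lies within the scatter). Compound 3 is estimated at 25000 nM, with an expected range of 8000 nM to 40000 nM.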

Compound 3, half-maximal cytotoxic concentration: > 30000 nM
Compound 3 gave a limit, no number (the forecaster's own chance of this, stated with the estimate: 60%); at least 1.2-fold (0.07 log units) between middle value and limit.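

No step can be read from compound 2 to compound 3 in this assay, since both results are limits and not numbers, and the series stands as follows: the limit of > 30000 nM in this assay, at which 3 of the 3 values shown sit.

The compounds shown leave open how 2-(methoxycarbonyl)ethenyl and 2-(methoxycarbonyl)ethyl compare in this assay, and which change to the series, if any, would give a number there.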